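Aryl piperazine series: cyano to cyclopropyl on the aryl ring

The source may hold more compounds than are shown below. What is called first, only, known or untested is meant among the compounds shown, and "the series" means these compounds.

Working notes on three measured compounds and one still to be measured. Compound 1 `COc1ccccc1N1CCN(CCCNc2ccncc2C(=O)N(C)C)CC1`, compound 2 `COc1ccccc1N1CCN(CCCNc2ccc(C(=O)N(C)C)cn2)CC1` and compound 3 `CN(C)C(=O)c1cccnc1NCCCN1CCN(c2ccccc2C#N)CC1` were all run in a functional assay on aorta for antagonist activity at Alpha-1D adrenergic receptor (Rattus norvegicus); a lower number here means tighter binding, a higher number weaker binding. In this assay compound 1 gives 50.1 nM, compound 2 gives 31.6 nM and compound 3 gives 10 nM. Compound 3 has the lowest number of the three; its gap to compound 2 and its wider gap to compound 1 both lie beyond the usual scatter, so compound 3 stands as the tightest binder of the set. No two of these three differ in only one place, so no single-point step can be read from the measured compounds.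

Compound 4 `CN(C)C(=O)c1cccnc1NCCCN1CCN(c2ccccc2C2CC2)CC1` differs from compound 3 in one place: cyclopropyl in place of cyano on an aromatic carbon. Cyano leaves and cyclopropyl enters on an aromatic carbon of a six-membered aromatic ring of carbon only. For the measured compounds named here, no measured pair shows this exchange, so nothing in the data fixes its size or direction. The expectation is a modest step in this assay toward a somewhat higher number, a 2.0-fold higher number from compound 3 to compound 4 (0.30 log units; within the scatter). The estimate for compound 4 in this assay is 20 nM, expected to fall between 5 nM and 80 nM.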

Compound 4, dissociation constant: 63.1 nM
Compound 4: middle estimate off by 3.2-fold (0.50 log units), on the low side; low and high end bracket the measured number.
By their numbers in this assay, from the lowest: compound 3; then compounds 2, 1 and 4 (each within the scatter of the next).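

In this assay, cyclopropyl in place of cyano on an aromatic carbon, ortho to a large group, gives a 6.3-fold higher number from compound 3 to compound 4 (0.80 log units; beyond the scatter). For the compounds shown here, this is the first single-place step, and it shows that with the rest of compound 3 held fixed, the number responds to the group at this position, so 2-cyanophenyl and 2-cyclopropylphenyl are not interchangeable here. The exchange replaces a nitrile, with a triple bond and one hydrogen-bond acceptor, by a three-membered carbon ring with no hydrogen-bond acceptor, but no measurement on hand separates these differences or ties the step to any one of them.

The compounds shown leave open how other groups at this position, such as methyl, chlorine or a primary amine, would sit relative to cyano and cyclopropyl, and so whether the step follows from losing the nitrile or from adding the carbon ring. Also open, from the compounds shown here alone, is whether the same exchange gives a step of similar size and direction on the cores of compound 1 and compound 2.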